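The source may report more compounds than this note shows. Statements on the series, on what has been measured and on what is new or still open speak of the compounds shown alone.

In an in vitro assay on HEK385-7 cells for displacement of a labelled ligand from prostaglandin D2 receptor 2 (Homo sapiens) (a higher number here means a weaker inhibitor, a lower number a stronger inhibitor), three compounds have been measured: compound 1 `O=C(O)Cc1sc(C(c2ccc(F)cc2)c2ccc(F)cc2)nc1-c1ccccc1` gives 16 nM, compound 2 `O=C(O)Cc1sc(C(c2ccc(F)cc2)c2ccc(F)cc2)nc1-c1ccoc1` gives 14 nM, and compound 3 `O=C(O)Cc1sc(C(c2ccc(F)cc2)c2ccc(F)cc2)nc1-c1ccncc1` gives 5.3 nM.

Compound 3 stands at the lowest number of the three, as shown by a 3.0-fold lower number from compound 1 to compound 3 (0.48 log units; beyond the scatter) and by a 2.6-fold lower number from compound 2 to compound 3 (0.42 log units; beyond the scatter), while a 1.1-fold lower number from compound 1 to compound 2 (0.06 log units; within the scatter) stays within the scatter. Compound 4 `O=C(O)Cc1sc(C(c2ccc(F)cc2)c2ccc(F)cc2)nc1-c1ccc(Cl)cc1` differs from compound 3 in one place: 4-chlorophenyl in place of pyridin-4-yl on an aromatic carbon. The step that bears most on this change is a 3.0-fold lower number from compound 1 to compound 3 (0.48 log units; beyond the scatter), since compound 4 returns to a carbon-only ring of the kind compound 1 carries. For the measured compounds named here, no measured compound carries a chlorine on this ring, so its effect is unknown. The expected step is therefore upward, a 2.5-fold higher number from compound 3 to compound 4 (0.39 log units; beyond the scatter). Compound 4 is estimated at 13 nM, with a range from 5 nM to 35 nM.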

Compound 4, half-maximal inhibitory concentration: 9.7 nM
Beside the measured number, compound 4's estimate is 1.3-fold (0.13 log units) above it, and the stated range covers the measured number.
By their numbers in this assay, from the lowest: compounds 3, 4, 2 and 1 (each within the scatter of the next, the first and the last beyond it).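

Compound 4 carries the only substituent on this ring among the compounds shown, and chloro in place of hydrogen gives a 1.6-fold lower number from compound 1 to compound 4 (0.22 log units; within the scatter), so this change cannot be told from the scatter. The 4-chlorophenyl group is likewise not separated from the other rings at this position, with a 1.8-fold higher number from compound 3 to compound 4 (0.26 log units; within the scatter) and a 1.4-fold lower number from compound 2 to compound 4 (0.16 log units; within the scatter). No measurement at hand offers an explanation for these numbers.

From the compounds shown here alone, it remains open whether a methoxy or dimethylamino group on this phenyl ring, or a piperidine ring in its place, would give a step beyond the scatter.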